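The source may report more compounds than this note shows. Statements on the series, on what has been measured and on what is new or still open speak of the compounds shown alone.

Measured compounds:
compound 1, `Fc1ccc(-c2nc3cccnc3o2)cc1`, gives 27%;
compound 2, `Brc1cccc(-c2nc3ncccc3o2)c1`, gives 23%.

In a functional assay on the whole organism for inhibition, with Rattus norvegicus as the target, at a dose of 30 mg/kg (a higher number here means more inhibition at the dose given (going by the name of the read-out), a lower number less inhibition), compound 2 holds the lowest of the two numbers, and its nearest neighbour, compound 1, lies within the scatter of it, so the two cannot be set in order. Compound 3, `O=[N+]([O-])c1cccc(-c2nc3ncccc3o2)c1`, differs from compound 2 by nitro in place of bromo on an aromatic carbon. For the measured compounds named here, no step between measured compounds is known in this assay, so nothing measured points in either direction for this exchange. The expectation is therefore a step of a number 2 percentage points higher from compound 2 to compound 3 (within the scatter), none beyond the scatter. Compound 3 is estimated at 25%, between 5% and 50%.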

Compound 3, a percentage reported as inhibition, in the whole organism at one dose (the size of the read-out at that dose, not a potency): 21%
Beside the measured number, compound 3's estimate is 4 percentage points above it; measured number inside the range.
By their numbers in this assay, from the lowest: compounds 3, 2 and 1 (each within the scatter of the next).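

With bromo replaced by nitro on this aromatic carbon, meta to a group of 9 heavy atoms, this assay shows a number 2 percentage points lower from compound 2 to compound 3 (within the scatter). The position therefore takes a group of 3 heavy atoms with 2 hydrogen-bond acceptors in place of a single bromine atom without a step beyond the scatter. Nothing measured here offers an explanation for this result. Still open, from the compounds shown here alone, is whether an amine or a carboxylic acid on the same carbon would give a step beyond the scatter.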